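The source may hold more compounds than are shown below. What is called first, only, known or untested is meant among the compounds shown, and "the series" means these compounds.

Measured so far in an assay on CHO cells, read by calcium flux; on this read-out lower numbers stand for stronger inhibition and higher numbers for weaker inhibition:
compound 1 `CC(C)c1ccc(NC(=O)c2csc(Cc3c(Cl)cccc3Cl)n2)cc1` — in this assay compound 1 gives 520 nM
compound 2 `CC(C)(C)c1ccc(NC(=O)c2csc(Cc3c(Cl)cccc3Cl)n2)cc1` — in this assay compound 2 gives 300 nM
compound 3 `O=C(Nc1ccccc1)c1csc(Cc2c(Cl)cccc2Cl)n1` — in this assay compound 3 gives > 4000 nM, a limit of the assay rather than a number.

Compound 3 therefore stands at the limit of > 4000 nM in this assay, at which 1 of the 3 values shown sits, alone among the three, the other two being measured numbers. Compound 4 `CN(C)c1ccc(NC(=O)c2csc(Cc3c(Cl)cccc3Cl)n2)cc1` differs from compound 3 by dimethylamino in place of hydrogen on an aromatic carbon. Going by the values given here, two measured steps bear on this change: an at least 7.6-fold higher number from compound 1 to compound 3 (0.88 log units; beyond the scatter) and an at least 13-fold higher number from compound 2 to compound 3 (1.12 log units; beyond the scatter). In both, hydrogen in place of a group on that aromatic carbon raised the number beyond the scatter; a group entering at the same place is expected to move it back down. Dimethylamino has not yet been tried here, so the size is uncertain. For compound 4 a lower number is expected, an at least 3.3-fold lower number from compound 3 to compound 4 (0.52 log units; beyond the scatter). Compound 4 is estimated at 1200 nM in this assay, within 350 nM to 4000 nM.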

Compound 4, half-maximal inhibitory concentration: 1270 nM
Beside the measured number, compound 4's estimate is 1.1-fold (0.02 log units) below it; the range from low to high includes it.
By their numbers in this assay, from the lowest: compounds 2 and 1 (each within the scatter of the next); then compound 4. At a limit, above all of these: compound 3.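

In this assay, dimethylamino on this aromatic carbon also lowers the number, an at least 3.1-fold lower number from compound 3 to compound 4 (0.49 log units; beyond the scatter), so the gain is not confined to isopropyl and tert-butyl. Compound 3 stands at a limit of the assay, which makes that step a bound only: the limit of > 4000 nM in this assay, at which 1 of the 4 values shown sits. Dimethylamino still falls short of both alkyl groups, a 2.4-fold higher number from compound 1 to compound 4 (0.39 log units; beyond the scatter) and a 4.2-fold higher number from compound 2 to compound 4 (0.63 log units; beyond the scatter), so the identity of the group counts here, not merely the presence of one.

Open, from the compounds shown here alone, is how methoxy, chlorine or a carboxylic acid would compare at this place. Also open, going by these compounds, is whether a primary amine would track dimethylamino.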